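Methoxy for Bromine on the Pyrazoline Aryl Group

The source may report more compounds than this note shows. Statements on the series, on what has been measured and on what is new or still open speak of the compounds shown alone.

Going by the values given here, compound 2 `CNC(=O)c1cc(Oc2ccc(C3=NNC(c4cccc(Br)c4)C3)cc2)ccn1` gives 3540 nM in a functional assay on PC-3 cells (Homo sapiens) for cytotoxicity, read by MTT assay, with a stated time of 72 h (a higher number here means a weaker inhibitor, a lower number a stronger inhibitor), the lowest of the two numbers measured so far. Its nearest neighbour is compound 1 `CNC(=O)c1cc(Oc2ccc(C3=NNC(c4ccc(Cl)cc4Cl)C3)cc2)ccn1`, which in this assay gives 7300 nM. Among the compounds with values here, the single measured step, a 2.1-fold lower number from compound 1 to compound 2 (0.31 log units; beyond the scatter), swaps one halogenated ring for another, and it is the only comparison available.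

Compound 3 `CNC(=O)c1cc(Oc2ccc(C3=NNC(c4ccc(OC)cc4)C3)cc2)ccn1` has not yet been measured. The change 4-methoxyphenyl in place of 3-bromophenyl on a saturated ring carbon replaces a halogen-bearing ring with one carrying a methoxy group and a hydrogen-bond acceptor. Within the data shown here, the one measured step bears only loosely on this change, since both of its rings carry halogens and neither carries a methoxy group; it shows that exchanging the aryl substituent on this carbon can move the number modestly. Among the measured compounds shown here, with no direct precedent, he expects no step beyond the scatter, and estimates a 1.3-fold higher number from compound 2 to compound 3 (0.10 log units; within the scatter) for compound 3. His estimate for compound 3 in this assay is therefore 4500 nM, with a range from 1500 nM to 14000 nM.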

Compound 3, half-maximal inhibitory concentration: 7740 nM
Compound 3: the middle estimate sits 1.7-fold (0.24 log units) below what was measured, within the range that was stated.
By their numbers in this assay, from the lowest: compound 2; then compounds 1 and 3 (each within the scatter of the next).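

Going by these compounds alone, exchanging 3-bromophenyl for 4-methoxyphenyl on this saturated ring carbon gives a 2.2-fold higher number from compound 2 to compound 3 (0.34 log units; beyond the scatter) in this assay, the first step here that takes a halogen-bearing ring to one with a methoxy group. Set against the dichlorinated ring, the same methoxy-bearing ring gives a 1.1-fold higher number from compound 1 to compound 3 (0.03 log units; within the scatter), so the 4-methoxyphenyl and 2,4-dichlorophenyl groups are not told apart at this position. Carrying halogen on the ring therefore does not by itself go with the lower number: compound 2 fits such a link, while compound 1 goes against it, and among these three aryl groups only the 3-bromophenyl group stands apart, by a modest margin. Nothing available explains this difference in the cell read-out.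

From the compounds shown here alone, what remains open is whether the bromine itself or its place on the ring goes with the lower number of compound 2. The compounds shown also leave open how a phenyl ring carrying an amine or a carboxylic acid would stand on this saturated ring carbon.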